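Working notes: from compound 2 to compound 3 in this series

A few compounds are considered here, and "the series" means these few. Any claim that something is new, unique, unknown or untested is made for them only; others in the source may bear on it.

Measured so far:
compound 1 `C=CCn1c(=O)/c(=C\c2ccc(Cl)c(Cl)c2)[nH]c(=O)/c1=C\c1ccccc1OC` — "not active" (no number reported)
compound 2 `C=CCn1c(=O)/c(=C\c2cccc(Br)c2)[nH]c(=O)/c1=C\c1ccccc1OC` — 5400 nM

For the measured compounds named here, in a functional assay on MCF7 cells (Homo sapiens) for cytotoxicity, read by CCK-8 assay, with a stated time of 72 h (on this read-out lower numbers stand for stronger inhibition and higher numbers for weaker inhibition), compound 2 gives 5400 nM, the only number recorded in the set. Going by the values given here, compound 1 gives "not active" (no number reported) in this assay, without a number attached, so no step between measured compounds can be counted and compound 2 stands alone as the sole quantified point.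

Compound 3 `C=CCn1c(=O)/c(=C\c2ccccc2C(F)(F)F)[nH]c(=O)/c1=C\c1ccccc1OC` differs from compound 2 by 2-(trifluoromethyl)phenyl in place of 3-bromophenyl on a double-bonded chain carbon bound to an aromatic carbon. Among the compounds with values here, no measured pair covers this change, so the expectation rests on the two entries alone. The step from compound 2 to compound 3 is expected to run toward weaker inhibition, a 1.9-fold higher number from compound 2 to compound 3 (0.27 log units; within the scatter), probably beyond the scatter. A return of no number at all is also a real possibility, since compound 1 gives "not active" (no number reported) in this assay. Compound 3 is estimated at 10000 nM, with a range from 2500 nM to 40000 nM.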

Compound 3, half-maximal inhibitory concentration: 6500 nM
Estimate against measurement, compound 3: 1.5-fold (0.19 log units) above; the measured number falls inside the stated range.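

In this assay, the aryl group on a double-bonded chain carbon bound to an aromatic carbon now has its first readable step: 2-(trifluoromethyl)phenyl in place of 3-bromophenyl gives a 1.2-fold higher number from compound 2 to compound 3 (0.08 log units; within the scatter) on the shared core. Two different substituted phenyl groups at this place therefore both return a number, and the two numbers cannot be told apart. No measured information bears on why this exchange leaves the number within the scatter.

Steps to compound 1, which gives "not active" (no number reported) in this assay, cannot be read, so what separates it from the two quantified compounds remains open. Also open, on these data alone, is what a carboxylic acid or an amine on this aromatic ring would return in place of the halogen and trifluoromethyl groups.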